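This account rests on a few compounds, and the source may have more. Where it says the series, first, only, none or still open, it means among the compounds named here.

Measured so far:
compound 1 `Cc1ccc(NC(=O)CCC(=O)OCCCCCCSc2ccc([N+](=O)[O-])c3nonc23)cc1` — 6800 nM
compound 2 `CN(C)CCCNC(=O)CCC(=O)OCCCCCCSc1ccc([N+](=O)[O-])c2nonc12` — 160 nM

In an assay on isolated protein for inhibition of glutathione S-transferase P (Homo sapiens), with a stated time of 10 min (a lower number here means a stronger inhibitor, a higher number a weaker inhibitor), compound 1 gives 6800 nM and compound 2 gives 160 nM, so compound 2 holds the lower of the two numbers, with the step of a 43-fold lower number from compound 1 to compound 2 (1.63 log units; beyond the scatter) well beyond the scatter. That step exchanges an aryl group on the amide nitrogen for an aminoalkyl chain; it says nothing about the length of that chain.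

Compound 3 `CN(C)CCNC(=O)CCC(=O)OCCCCCCSc1ccc([N+](=O)[O-])c2nonc12` is not yet measured. It differs from compound 2 by dimethylamino in place of (dimethylamino)methyl on a saturated chain carbon, two bonds along the chain from an amide-type nitrogen; the amide nitrogen and the dimethylamino group stay, only the spacing between them is shortened by one chain carbon. Within the data shown here, no measured step covers such a shortening, and the single step of a 43-fold lower number from compound 1 to compound 2 (1.63 log units; beyond the scatter) gives no guide to its direction. The expected step is therefore none beyond the scatter, a 1.3-fold higher number from compound 2 to compound 3 (0.10 log units; within the scatter). Compound 3 is estimated at 200 nM, in the range 60 nM to 650 nM.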

Compound 3, half-maximal inhibitory concentration: 540 nM
The estimate for compound 3 lay 2.7-fold (0.43 log units) below the measured number; low and high end bracket the measured number.
By their numbers in this assay, from the lowest: compound 2; then compound 3; then compound 1.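

In this assay, the length of the chain on the amide nitrogen has a readable effect: shortening 3-(dimethylamino)propyl to 2-(dimethylamino)ethyl gives a modest step (a 3.4-fold higher number from compound 2 to compound 3 (0.53 log units; beyond the scatter)). The shorter chain still retains much of the large difference from the 4-methylphenyl amide (a 13-fold lower number from compound 1 to compound 3 (1.10 log units; beyond the scatter)), so both dimethylaminoalkyl chains shown give lower numbers than the aryl group, and the 3-(dimethylamino)propyl chain gives the lowest. Nothing available here accounts for the difference between the two chain lengths.

Open, going by these compounds, is whether a longer chain, such as 4-(dimethylamino)butyl, would lower the number further or reverse the direction. Also open, on these data alone, is how much depends on the dimethylamino group itself, which a primary amine, a morpholine or a carboxylic acid at the chain end would test.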